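From allyl to carbamoyl on the shared core

The source may report more compounds than this note shows. Statements on the series, on what has been measured and on what is new or still open speak of the compounds shown alone.

Compound 1 `CCCn1c(=O)n(CCCN(C)C)c(=O)c2[nH]cnc21` gives 20500 nM
Compound 2 `CCCn1c(=O)n(CCOCC)c(=O)c2[nH]cnc21` gives 70 nM
Compound 3 `C=CCCn1cnc2c1c(=O)n(C)c(=O)n2CCC` gives 16800 nM

In a functional assay (trachea) with Cavia porcellus as the target (on this read-out higher numbers stand for an effect only at larger amounts of compound and lower numbers for an effect already at smaller amounts), compound 3 lies within the usual scatter of compound 1, and both stand far above compound 2. Compound 4 `CCCn1c(=O)n(C)c(=O)c2c1ncn2CC(N)=O` differs from compound 3 by carbamoyl in place of allyl on a saturated chain carbon bound to an aromatic nitrogen. For the measured compounds named here, only one measured step bears on this, and only loosely: a 290-fold lower number from compound 1 to compound 2 (2.47 log units; beyond the scatter). It involves a different exchange, so it shows that such a swap can move the number far, but it gives no direction here. Going by the values given here, no measured compound carries carbamoyl. In this assay a modest step toward a higher number is expected, estimated as a 2.4-fold higher number from compound 3 to compound 4 (0.38 log units; beyond the scatter). For compound 4 the estimate is 40000 nM, with an expected range from 10000 nM to 150000 nM.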

Compound 4, half-maximal effective concentration: > 100000 nM
Compound 4 ended at the assay's limit; the forecaster's own chance of this, stated with the estimate: 15%; middle value at least 2.5-fold (0.39 log units) away from the limit.
By their numbers in this assay, from the lowest: compound 2; then compounds 3 and 1 (each within the scatter of the next). At a limit, above all of these: compound 4.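

In this assay, carbamoyl in place of allyl on a saturated chain carbon bound to an aromatic nitrogen gives an at least 5.9-fold higher number from compound 3 to compound 4 (0.77 log units; beyond the scatter). For the compounds shown here, the earlier compounds showed only that a different exchange could move the number far, whereas this step gives a direction for this change at this place. The value of compound 4 is a limit of the assay, not a number: the limit of > 100000 nM in this assay, at which 1 of the 4 values shown sits.

As far as these compounds go, it remains open how an amine or a carboxylic acid in this place would read. From the compounds shown here alone, it is equally open whether a longer chain carrying the carbamoyl would change the number.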